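A repeated phenyl swap on compound 3

The compounds below may be only part of what the source reports. "The series", "measured", "known", "first", "only" and "open" are said of these compounds alone.

In a functional assay on SMMC-7721 cells (Homo sapiens) for cytotoxicity, read by MTT assay, with a stated time of 24 h (on this read-out higher numbers stand for weaker inhibition and lower numbers for stronger inhibition), compound 3 `CN1C/C(=C\c2ccncc2)C(=O)/C(=C/c2ccccc2F)C1` gives 7000 nM. Compound 1 `CN1C/C(=C\c2cccnc2)C(=O)/C(=C/c2ccccc2F)C1` gives 5420 nM, and the two count as level: a 1.3-fold higher number from compound 1 to compound 3 (0.11 log units; within the scatter). Compound 2 `CN1C/C(=C\c2cccnc2)C(=O)/C(=C/c2ccc(F)cc2Br)C1` gives a higher number, 20800 nM.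

Compound 4 `CN1C/C(=C\c2ccncc2)C(=O)/C(=C/c2ccc(F)cc2Br)C1` differs from compound 3 in one place, on a double-bonded chain carbon bound to a double-bonded ring carbon: 2-bromo-4-fluorophenyl in place of 2-fluorophenyl on a double-bonded chain carbon bound to a double-bonded ring carbon. There, 2-bromo-4-fluorophenyl stands in place of 2-fluorophenyl.

The same swap has been measured only once, and it gave a 3.8-fold higher number from compound 1 to compound 2 (0.58 log units; beyond the scatter). A step of similar size towards weaker inhibition is therefore expected in this assay, estimated as a 3.6-fold higher number from compound 3 to compound 4 (0.55 log units; beyond the scatter). Compound 4 is estimated at 25000 nM, with an expected range of 10000 nM to 60000 nM.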

Compound 4, half-maximal inhibitory concentration: 23800 nM
Compound 4: middle estimate off by 1.1-fold (0.02 log units), on the high side, within the range that was stated.
By their numbers in this assay, from the lowest: compounds 1 and 3 (each within the scatter of the next); then compounds 2 and 4 (each within the scatter of the next).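

The swap to 2-bromo-4-fluorophenyl gives a 3.4-fold higher number from compound 3 to compound 4 (0.53 log units; beyond the scatter) in this assay, so the move towards weaker inhibition at this position does not depend on which pyridine the core carries: the same change on two cores in this assay, a 3.8-fold higher number (0.58 log units; beyond the scatter) from compound 1 to compound 2 and a 3.4-fold higher number (0.53 log units; beyond the scatter) from compound 3 to compound 4, 1.1-fold (0.05 log units) apart, within the scatter of two such steps. The change from pyridin-3-yl to pyridin-4-yl, which left compounds 1 and 3 level, also leaves the 2-bromo-4-fluorophenyl pair level, with a 1.1-fold higher number from compound 2 to compound 4 (0.06 log units; within the scatter): the same change on two cores in this assay, a 1.3-fold higher number (0.11 log units; within the scatter) from compound 1 to compound 3 and a 1.1-fold higher number (0.06 log units; within the scatter) from compound 2 to compound 4, 1.1-fold (0.05 log units) apart, within the scatter of two such steps.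

These compounds cannot separate the effect of the bromine from that of the added fluorine. Going by these compounds, how an amine or a carboxylic acid on this phenyl ring would read remains open.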